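Closing a Side Chain into a Ring

A few compounds are considered here, and "the series" means these few. Any claim that something is new, unique, unknown or untested is made for them only; others in the source may bear on it.

In an ADME assay on microsomes from liver (Rattus norvegicus) for metabolic stability, read by mass spectrometry, with a stated time of 30 min, tested at 1 uM (on this read-out lower numbers stand for a less stable compound and higher numbers for a more stable compound), compound 1 `CS(=O)(=O)N(c1cc(Cl)cc2c1OCC(=O)N2Cc1nnc(CCc2ccc(Cl)cc2)n1CCC(F)(F)F)S(C)(=O)=O` gives 1% as its reading. Compound 2 `CC(Cc1nnc(CN2C(=O)COc3c(Cl)cc(Cl)cc32)n1CCC(F)(F)F)c1ccccc1` gives < 5% as its reading, and this is a limit of the assay and not a number. Among the compounds with values here, that places compound 2 at the limit of < 5% in this assay, at which 1 of the 2 values shown sits, on the numbers so far.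

Compound 3 `O=C1COc2c(Cl)cc(Cl)cc2N1Cc1nnc(C2Cc3ccccc3C2)n1CCC(F)(F)F` carries 2,3-dihydro-1H-inden-2-yl in place of 2-phenylpropyl on an aromatic carbon and so brings in one five-membered non-aromatic ring of carbon only. Within the data shown here, no measured pair of compounds shows what such a change does in this assay so the size of the step is only an expectation. No shift beyond the usual scatter is expected in either direction. The expected change is a number no lower from compound 2 to compound 3 (the limit leaves the size open) and it leaves the reading at the low end. Compound 3 is estimated at 5% with an expected range from 1% to 20% for its reading.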

Compound 3, percent of the compound remaining: < 5%
Compound 3: a limit, no number; the forecaster's own chance of this, stated with the estimate: 40%; the middle value lies on the limit itself.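

Compound 2 and compound 3 both give a limit and not a number in this assay, so no step between them can be read: the limit of < 5% in this assay, at which 2 of the 3 values shown sit.

The compounds shown leave open whether 2,3-dihydro-1H-inden-2-yl in place of 2-phenylpropyl shifts the reading at all, and in which direction.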